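The compounds below may be only part of what the source reports. "The series", "measured", "known", "first", "only" and "open" are said of these compounds alone.

Three measured compounds share one core, built from two linked saturated nitrogen-containing rings and a sulfonyl group, and differ only in the aromatic group attached to the sulfonyl sulfur. In an ADME assay on HCT-116 cells (Homo sapiens) for cytotoxicity, read by CellTiter-Glo, with a stated time of 72 h (a higher number here means a weaker inhibitor, a lower number a stronger inhibitor), compound 1 `CC1CCN(C2CCN(S(=O)(=O)c3cccc(-c4ccccc4F)c3)CC2)CC1` gives > 5000 nM, which is a limit of the assay rather than a number. Compound 2 `CC1CCN(C2CCN(S(=O)(=O)c3sc(Cl)nc3C3CC3)CC2)CC1` gives in this assay > 10000 nM, again a limit. Compound 3 `CC1CCN(C2CCN(S(=O)(=O)c3cnc(Cl)s3)CC2)CC1` gives in this assay > 10000 nM, also a limit. Within the data shown here, the single step among measured compounds, a step that the two limits leave unreadable from compound 2 to compound 3, therefore cannot be read, as both ends sit at limits. Compound 3 thus stands where most of the series sits: at the limit of > 10000 nM in this assay, at which 2 of the 3 values shown sit, while compound 1 sits at the limit of > 5000 nM in this assay, at which 1 of the 3 values shown sits.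

Compound 4 `CC1CCN(C2CCN(S(=O)(=O)c3cccnc3F)CC2)CC1` arises from compound 3 through the change (2-fluoropyridin-3-yl in place of 2-chloro-1,3-thiazol-5-yl on a sulfonyl sulfur). Among the measured compounds shown here, no measured step bears on this change, and the one step that exists in this assay, a step that the two limits leave unreadable from compound 2 to compound 3, is unreadable. Every aromatic group tried so far on the sulfonyl sulfur has left the compound at a limit, so compound 4 is expected to remain weak in this assay as well. The step that the limit leaves unreadable from compound 3 to compound 4 is thus estimated to stay within the scatter. For compound 4 the estimated value is 15000 nM, with a range from 5000 nM to 50000 nM.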

Compound 4, half-maximal inhibitory concentration: > 10000 nM
Compound 4 gave a limit, no number (the forecaster's own chance of this, stated with the estimate: 85%); the middle value lies beyond the limit too.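

In this assay, compound 3 and compound 4 both end at a limit of the assay rather than at a number, so the step between them cannot be read. The compounds shown leave open whether any aromatic group on the sulfonyl sulfur of the shared core would give a measurable value there.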